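The compounds below may be only part of what the source reports. "The series", "measured", "known", "first", "only" and "open" are said of these compounds alone.

Three compounds have been measured in a functional assay on MCF7 cells (Homo sapiens) for antiproliferative activity, read by MTT assay, with a stated time of 72 h; a higher number here means a weaker inhibitor, a lower number a stronger inhibitor:

compound 1 `CCCSc1nc(N/N=C/c2ccccc2Cl)c2nnn(Cc3ccccc3)c2n1`: 13800 nM
compound 2 `CCCSc1nc(N/N=C/c2cccs2)c2nnn(Cc3ccccc3)c2n1`: > 64000 nM, which is a limit of the assay and not a number
compound 3 `CCCSc1nc(N/N=C(\C)c2ccc(O)cc2)c2nnn(Cc3ccccc3)c2n1`: 21600 nM

Among the compounds with values here, compound 2 therefore stands at the top of the measured range; it is the one compound sitting at the limit of > 64000 nM in this assay, at which 1 of the 3 values shown sits, so its true value is unknown beyond that bound. Compound 4 `CCCSc1nc(N/N=C/c2c[nH]c3ccccc23)c2nnn(Cc3ccccc3)c2n1` differs from it by 1H-indol-3-yl in place of thiophen-2-yl on a carbon with a double bond to nitrogen. Within the data shown here, two measured steps bear on this change, since both replace or introduce the thiophen-2-yl group on the same carbon: an at least 4.6-fold higher number from compound 1 to compound 2 (0.66 log units; beyond the scatter) and an at least 2.9-fold lower number from compound 2 to compound 3 (0.47 log units; beyond the scatter). In each case the compound bearing the thiophen-2-yl group gave the higher number, and the compound bearing a group containing a six-membered aromatic ring of carbon only gave the lower one. The indol-3-yl group entering in compound 4 also contains such a six-membered ring, so a step towards a lower number is expected, an at least 4.2-fold lower number from compound 2 to compound 4 (0.63 log units; beyond the scatter). Compound 4 is accordingly estimated at 15000 nM, within 5000 nM to 55000 nM.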

Compound 4, half-maximal inhibitory concentration: 9010 nM
Estimate against measurement, compound 4: 1.7-fold (0.22 log units) above; measured number inside the range.
By their numbers in this assay, from the lowest: compounds 4, 1 and 3 (each within the scatter of the next, the first and the last beyond it). At a limit, above all of these: compound 2.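

In this assay, compound 2 gives > 64000 nM, which is a limit of the assay and not a number. Even so, 1H-indol-3-yl in place of thiophen-2-yl on this carbon brings an at least 7.1-fold lower number from compound 2 to compound 4 (0.85 log units; beyond the scatter), while 1H-indol-3-yl in place of 2-chlorophenyl gives only a 1.5-fold lower number from compound 1 to compound 4 (0.19 log units; within the scatter), so these two groups are not told apart here. Compound 4 also holds a five-membered aromatic ring with 1 hetero atom, so such a ring on this carbon does not by itself go with a number at the limit.

The compounds shown leave open whether the step follows the six-membered ring of 1H-indol-3-yl or its hydrogen-bond donor, which a 1-methylindol-3-yl or benzothiophen-3-yl group could separate. They also leave open how a longer chain or an amine elsewhere on the shared core would read.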